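This account rests on a few compounds, and the source may have more. Where it says the series, first, only, none or still open, it means among the compounds named here.

Measured compounds in the series:

Compound 1 `C#Cc1cccc(Nc2ncnc3ccc(OCc4ccc(C(=O)Nc5ccccc5N)cc4)cc23)c1` gives > 100000 nM in an assay on isolated protein for inhibition of serine/threonine-protein kinase PLK1 (Homo sapiens) (a lower number here means a stronger inhibitor, a higher number a weaker inhibitor), a limit of the assay and not a number.
Compound 2 `Nc1ccccc1NC(=O)c1ccc(COc2ccc3ncnc(Nc4cccc(Br)c4)c3c2)cc1` gives > 100000 nM in this assay, again a limit.
Compound 3 `C#Cc1cccc(Nc2ncnc3ccc(S(=O)(=O)n4ccc(/C=C/C(=O)Nc5ccccc5N)c4)cc23)c1` gives 27000 nM in this assay.

For the measured compounds named here, compound 3 therefore holds the only read number in the set; compounds 1 and 2 both sit at the limit of > 100000 nM in this assay, at which 2 of the 3 values shown sit. Going by the values given here, the single step between measured compounds is a step that the two limits leave unreadable from compound 1 to compound 2, and it tells nothing about the amide end of the molecule, which is where the next change falls.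

Compound 4 `C#Cc1cccc(Nc2ncnc3ccc(S(=O)(=O)n4ccc(/C=C/C(=O)NO)c4)cc23)c1` differs from compound 3 by hydroxy in place of 2-aminophenyl on an amide-type nitrogen. Among the compounds with values here, no measured step touches this part of the structure, so there is no measured guidance on the size or direction of the change. From compound 3 to compound 4 the step is expected to be a 1.5-fold higher number from compound 3 to compound 4 (0.17 log units; within the scatter), with the outcome uncertain on both sides of the scatter. Compound 4 is accordingly expected at 40000 nM, within a range from 10000 nM to 100000 nM.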

Compound 4, half-maximal inhibitory concentration: > 100000 nM
Compound 4: only a limit was reported (the forecaster's own chance of this, stated with the estimate: 35%); at least 2.5-fold (0.39 log units) between middle value and limit.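

For the compounds shown here, on the amide-type nitrogen, in this assay, hydroxy in place of 2-aminophenyl gives an at least 3.7-fold higher number from compound 3 to compound 4 (0.56 log units; beyond the scatter), the first readable step and the only one at this position. Compound 4 gives > 100000 nM, a limit of the assay and not a number. Within this pair, the read value therefore belongs to the 2-aminophenyl amide, while the hydroxy compound falls at the same limit as compounds 1 and 2: the limit of > 100000 nM in this assay, at which 3 of the 4 values shown sit.

Going by these compounds alone, the full size of the step stays open, and the one earlier step, between two limits, cannot be read. Also open, from the compounds shown here alone, is whether the 2-aminophenyl group as a whole matters or only its amine, a question that an unsubstituted phenyl or a 2-hydroxyphenyl on the same nitrogen would address.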